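Swapping a 4-Fluorobenzyl for a 2-Chlorobenzyl Arm

This account rests on a few compounds, and the source may have more. Where it says the series, first, only, none or still open, it means among the compounds named here.

Compound 2 `CN(Cc1nc(C2CCN(Cc3ccc(F)cc3)CC2)no1)c1ncc(C(=O)NO)cn1` was tested in an assay on isolated protein for inhibition of protein deacetylase HDAC6 (Homo sapiens), read by fluorescence, with a stated time of 1 h, tested at 100 nM (on this read-out lower numbers stand for less inhibition and higher numbers for more inhibition at the one concentration tested (going by the name of the read-out)), where compound 2 gives 65%. Going by the values given here, its only neighbour, compound 1 `CN(Cc1nc(C2CCN(Cc3ccccc3)CC2)no1)c1ncc(C(=O)NO)cn1`, gives 63% in this assay, and the two are separated by a number 2 percentage points higher from compound 1 to compound 2 (within the scatter). Compound 3 `CN(Cc1nc(C2CCN(Cc3ccccc3Cl)CC2)no1)c1ncc(C(=O)NO)cn1` has not yet been measured; it differs from compound 2 by 2-chlorophenyl in place of 4-fluorophenyl on a saturated chain carbon bound to an amine nitrogen in a ring. Among the compounds with values here, the one measured step that bears on this kind of change, the one from compound 1 to compound 2, was small, so no movement beyond the scatter is expected in this assay. Compound 3 is therefore estimated at 65%, with a range from 52% to 76%, an expected step of no change at the digits printed from compound 2 to compound 3 (within the scatter).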

Compound 3, a percentage reported as inhibition, at one concentration (the size of the read-out at that concentration, not a potency): 55%
The estimate for compound 3 lay 10 percentage points above the measured number; low and high end bracket the measured number.
By their numbers in this assay, from the lowest: compounds 3, 1 and 2 (each within the scatter of the next).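

In this assay the 2-chlorobenzyl arm gives a number 10 percentage points lower from compound 2 to compound 3 (within the scatter), and against the unsubstituted benzyl arm it gives a number 8 percentage points lower from compound 1 to compound 3 (within the scatter). At this place, on a saturated chain carbon bound to an amine nitrogen in a ring, a chloro-bearing arm therefore joins the fluoro-bearing and unsubstituted arms, and this read-out does not separate the three beyond the scatter. Nothing available explains these numbers. Still open, on these data alone, is whether a phenyl carrying an amine or a carboxylic acid, or a longer chain in place of the benzyl carbon, would move the number beyond the scatter.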